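The source may report more compounds than this note shows. Statements on the series, on what has been measured and on what is new or still open speak of the compounds shown alone.

Measured so far:
- compound 1 `COc1cc(OC)c(/C=C/S(=O)(=O)Cc2ccc(OC)c(NC(C(=O)O)c3ccccc3)c2)c(OC)c1`: 15 nM
- compound 2 `COc1cc(OC)c(/C=C/S(=O)(=O)Cc2ccc(OC)c(NC(C(=O)O)c3ccc(Cl)cc3)c2)c(OC)c1`: 250 nM

In a functional assay on K562 cells (Homo sapiens) for cytotoxicity, read by trypan blue exclusion, with a stated time of 96 h (on this read-out lower numbers stand for stronger inhibition and higher numbers for weaker inhibition), compound 2 gives 250 nM, the higher of the two numbers. Compound 3 `COc1cc(OC)c(/C=C/S(=O)(=O)Cc2ccc(OC)c(NC(C(=O)O)c3ccc(Br)cc3)c2)c(OC)c1` differs from compound 2 by one change: bromo in place of chloro on an aromatic carbon. Among the measured compounds shown here, the only measured step that bears on this is a 17-fold higher number from compound 1 to compound 2 (1.22 log units; beyond the scatter), a large one, but it put chloro in place of hydrogen. No exchange of chloro for bromo has been measured. Going by that large step to compound 2, only a small change is expected here, with no shift in either direction beyond the scatter. The expected step is a 1.2-fold higher number from compound 2 to compound 3 (0.08 log units; within the scatter). For compound 3 the estimated value is 300 nM, within an expected range of 100 nM to 900 nM.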

Compound 3, half-maximal inhibitory concentration: 200 nM
Beside the measured number, compound 3's estimate is 1.5-fold (0.18 log units) above it; the range from low to high includes it.
By their numbers in this assay, from the lowest: compound 1; then compounds 3 and 2 (each within the scatter of the next).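

In this assay, bromo in place of chloro, para to a large group, gives a 1.3-fold lower number from compound 2 to compound 3 (0.10 log units; within the scatter) and so leaves the number within the scatter. Bromo in place of hydrogen gives a 13-fold higher number from compound 1 to compound 3 (1.12 log units; beyond the scatter) and is a large step like a 17-fold higher number from compound 1 to compound 2 (1.22 log units; beyond the scatter), so among these compounds the large rise is not confined to chloro. Nothing at hand explains these steps. Going by these compounds, whether fluoro, methyl or an amine at this place would stay close to compound 1 or fall with compound 2 and compound 3 remains open.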